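Third methoxy on the benzylidene ring of compound 2

The compounds below may be only part of what the source reports. "The series", "measured", "known", "first", "only" and "open" are said of these compounds alone.

Of the compounds shown here, three of one series have been measured in an assay for inhibition of Alpha amylase (Homo sapiens), with a stated time of 10 min; a lower number here means a stronger inhibitor, a higher number a weaker inhibitor. Compound 1 `COc1ccc(/C=C2/C(=O)N(c3ccc(Cl)cc3)N=C2C)cc1OC` gives 2030 nM. Compound 2 `COc1cc(/C=C2/C(=O)N(c3ccc(Cl)cc3)N=C2C)cc(OC)c1` gives 2210 nM. Compound 3 `COc1ccc(/C=C2/C(=O)N(c3ccc(Cl)cc3)N=C2C)c(OC)c1OC` gives 2100 nM. Compound 2 cannot be told apart from compound 1 or compound 3 on these numbers: the whole spread across the three lies within the scatter of repeated measurements, so no ranking among them is supported.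

The next compound, compound 4 `COc1cc(/C=C2/C(=O)N(c3ccc(Cl)cc3)N=C2C)cc(OC)c1OC`, has not yet been measured in this assay. Compared with compound 2 it carries methoxy in place of hydrogen on an aromatic carbon. For the measured compounds named here, one measured step bears on this change: a 1.0-fold higher number from compound 1 to compound 3 (0.01 log units; within the scatter), which is the same exchange of hydrogen for methoxy on the aromatic ring and left the number unchanged within the scatter. Going by the values given here, no other pair differs in a single place. On that basis the added methoxy in compound 4 is expected to leave the number where compound 2 already stands, giving an expected step of a 1.0-fold lower number from compound 2 to compound 4 (0.00 log units; within the scatter), which is no step beyond the scatter. The estimate for compound 4 in this assay is therefore 2200 nM, with a range from 1200 nM to 4200 nM.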

Compound 4, half-maximal inhibitory concentration: 2190 nM
Estimate against measurement, compound 4: 1.0-fold (0.00 log units) above; measured number inside the range.
By their numbers in this assay, from the lowest: compounds 1, 3, 4 and 2 (each within the scatter of the next).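

Methoxy in place of hydrogen on an aromatic carbon, ortho to two methoxy groups and para to a large group, gives a 1.0-fold lower number from compound 2 to compound 4 (0.00 log units; within the scatter) in this assay, so this position accepts the added group with no readable shift on the core of compound 2. The same exchange, read on the core of compound 1, gives a 1.1-fold higher number from compound 1 to compound 4 (0.03 log units; within the scatter), so this position shows no readable shift from either starting arrangement of methoxy groups. The exchange now has readings at two different places on the ring, and neither moves the number beyond the scatter: the same change on two cores in this assay, a 1.0-fold higher number (0.01 log units; within the scatter) from compound 1 to compound 3 and a 1.0-fold lower number (0.00 log units; within the scatter) from compound 2 to compound 4, 1.0-fold (0.02 log units) apart, within the scatter of two such steps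

All the compounds shown carry only methoxy groups on this ring, so it remains open whether this position stays as flat with a different group, such as a hydroxyl, an amine or a carboxylic acid. For the compounds shown here, it also remains open how far the number depends on the methoxy groups at all, as the series holds no member with an unsubstituted ring to set against them.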